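A few compounds are considered here, and "the series" means these few. Any claim that something is new, unique, unknown or untested is made for them only; others in the source may bear on it.

Compound 1 `CC1=CC[C@H](C(C)(C)NC(=S)N/N=C/c2ccccc2O)CC1` carries a 2-hydroxyphenyl on the carbon with a double bond to nitrogen, and in a functional assay on K562 cells (Homo sapiens) for inhibition, read by sulforhodamine B assay, with a stated time of 48 h (a higher number here means a weaker inhibitor of growth, a lower number a stronger inhibitor of growth), compound 1 gives 800 nM. Compound 2 `CC1=CC[C@H](C(C)(C)NC(=S)N/N=C/c2ccc(F)cc2)CC1` bears a 4-fluorophenyl in that place. In this assay compound 2 reaches only a limit, > 100000 nM. The step of an at least 120-fold higher number from compound 1 to compound 2 (2.09 log units; beyond the scatter) is thus known only from its lower bound, as the limit of > 100000 nM in this assay, at which 1 of the 2 values shown sits, marks. Compound 3 `CC1=CC[C@H](C(C)(C)NC(=S)N/N=C/c2ccc[nH]2)CC1` differs from compound 2 by 1H-pyrrol-2-yl in place of 4-fluorophenyl on a carbon with a double bond to nitrogen. Among the measured compounds shown here, the single measured step shows that exchanging the group on this carbon can move the number a great deal, and the incoming 1H-pyrrol-2-yl carries 1 hydrogen-bond donor, as the 2-hydroxyphenyl of compound 1 does. The step of an at least 5.0-fold lower number from compound 2 to compound 3 (0.69 log units; beyond the scatter) is expected to run downward, though with wide uncertainty and a real chance of another limit. Compound 3 is estimated at 20000 nM, within 3000 nM to 100000 nM.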

Compound 3, concentration for 50% growth inhibition: 23400 nM
Compound 3: the middle estimate sits 1.2-fold (0.07 log units) below what was measured; the measured number falls inside the stated range.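

In this assay, the 1H-pyrrol-2-yl gives a number that can be read at this position on the carbon with a double bond to nitrogen, with an at least 4.2-fold lower number from compound 2 to compound 3 (0.63 log units; beyond the scatter). Compound 2 stands only at a limit, so that step is a bound and not a full size: the limit of > 100000 nM in this assay, at which 1 of the 3 values shown sits. The 1H-pyrrol-2-yl and the 2-hydroxyphenyl both carry a hydrogen-bond donor, yet the two compounds are not level, with a 29-fold higher number from compound 1 to compound 3 (1.47 log units; beyond the scatter), so having a donor in this place does not alone match compound 1.

The compounds shown leave open whether the hydroxyl or the six-membered ring accounts for the low number of compound 1. A plain phenyl, a 2-methoxyphenyl or a 2-aminophenyl in this place would begin to separate the two.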